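Swapping the Side Chain of Compound 1

This account rests on a few compounds, and the source may have more. Where it says the series, first, only, none or still open, it means among the compounds named here.

Compound 1 `NC(=O)CN1CCN(c2nc(-c3cccnc3)nc3c2CN(Cc2ccccc2)CC3)CC1` was examined in an assay on cells with Cystic fibrosis transmembrane conductance regulator variant F508del (Homo sapiens) as the target, read by fluorescence, with stated times of 24 h and 30 min (on this read-out lower numbers stand for an effect already at smaller amounts and higher numbers for an effect only at larger amounts of compound), where compound 1 gives 100000 nM. That number is level, at the digits shown, with compound 2 `COc1ccc(CN2CCc3nc(-c4ccccn4)nc(N4CCN(CCN(C)C)CC4)c3C2)cc1`, which in this assay gives 100000 nM, and the two together are the highest of the three numbers known here; compound 3 `Cc1nc(NC(=O)C(C)(C)C)sc1-c1cc(Cc2ccccc2)n(C(=O)NCc2ccccc2)n1` stands apart, giving 759 nM in this assay. Compound 4 `CN(C)CCN1CCN(c2nc(-c3cccnc3)nc3c2CN(Cc2ccccc2)CC3)CC1` differs from compound 1 by a single change: (dimethylamino)methyl in place of carbamoyl on a saturated chain carbon bound to an amine nitrogen in a ring. The group that enters is one compound 2 already carries, and compound 2 sits at the same number as compound 1, so a step of no change at the digits printed from compound 1 to compound 4 (within the scatter) is expected, none beyond the scatter. Compound 4 is therefore expected to give 100000 nM, within a range from 30000 nM to 100000 nM.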

Compound 4, half-maximal effective concentration: 100000 nM
Compound 4: the middle estimate sits on the measured number at the digits printed; measured number inside the range.
By their numbers in this assay, from the lowest: compound 3; then compounds 1, 2 and 4 (each within the scatter of the next).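

In this assay, putting (dimethylamino)methyl in place of carbamoyl gives no change at the digits printed from compound 1 to compound 4 (within the scatter), so the two groups are not told apart at this place on the shared core. Within the data shown here, compound 2 carries the same group but differs from compound 1 in more than one place, so only this pair reads the change on its own. Nothing on hand accounts for this result. Going by these compounds, whether a carboxylic acid or a longer chain at this place would move the number remains open.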